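From dimethylphenyl to bromoindole in a growth inhibition series

The source may report more compounds than this note shows. Statements on the series, on what has been measured and on what is new or still open speak of the compounds shown alone.

Compound 1 `Cc1ccc(CS/C(=C/c2ccc(F)c(C)c2)C(=O)c2ccc(Cl)cc2)cc1`, compound 2 `Cc1ccc(CS/C(=C/c2c(O)cc(O)cc2O)C(=O)c2ccc(Cl)cc2)cc1` and compound 3 `Cc1ccc(CS/C(=C/c2cc(C)ccc2C)C(=O)c2ccc(Cl)cc2)cc1` differ only in the group on a double-bonded chain carbon bound to a double-bonded chain carbon. In a functional assay on DU-145 cells (Homo sapiens) for inhibition, read by trypan blue exclusion, with a stated time of 96 h (a higher number here means a weaker inhibitor of growth, a lower number a stronger inhibitor of growth), compound 1 gives 25000 nM, compound 2 gives 50000 nM and compound 3 gives 10000 nM, the lowest of the three numbers. Compound 4 `Cc1ccc(CS/C(=C/c2c[nH]c3ccc(Br)cc23)C(=O)c2ccc(Cl)cc2)cc1` carries 5-bromo-1H-indol-3-yl in place of 2,5-dimethylphenyl at that same place: 5-bromo-1H-indol-3-yl in place of 2,5-dimethylphenyl on a double-bonded chain carbon bound to a double-bonded chain carbon. The measured exchanges there stayed small, with a 2.0-fold higher number from compound 1 to compound 2 (0.30 log units; within the scatter), a 2.5-fold lower number from compound 1 to compound 3 (0.40 log units; beyond the scatter) and a 5.0-fold lower number from compound 2 to compound 3 (0.70 log units; beyond the scatter). For the measured compounds named here, none of the measured compounds carries an indole, so the direction remains open, and no change beyond the scatter is expected, the expected step being a 1.3-fold lower number from compound 3 to compound 4 (0.10 log units; within the scatter). For compound 4 the estimated value is 8000 nM, with an expected range of 2000 nM to 30000 nM.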

Compound 4, concentration for 50% growth inhibition: 1000 nM
For compound 4 the middle estimate is 8.0-fold (0.90 log units) above the measured one; the whole stated range lies above it.
By their numbers in this assay, from the lowest: compound 4; then compound 3; then compounds 1 and 2 (each within the scatter of the next).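

For the compounds shown here, at this place, on a double-bonded chain carbon bound to a double-bonded chain carbon, 5-bromo-1H-indol-3-yl opens a wider spread in this assay than any exchange among the earlier compounds, with a 10-fold lower number from compound 3 to compound 4 (1.00 log units; beyond the scatter) and with larger steps of a 25-fold lower number from compound 1 to compound 4 (1.40 log units; beyond the scatter) and a 50-fold lower number from compound 2 to compound 4 (1.70 log units; beyond the scatter) as well. Compound 4 is therefore the strongest growth inhibitor of the four, and the only one here with two aromatic rings in this group. Nothing available explains this gain.

On these data alone, whether it follows the bromine or the indole stays open. An unsubstituted 1H-indol-3-yl, a 5-chloro-1H-indol-3-yl or a 1-methylindol-3-yl group would begin to separate these parts.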